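This account rests on a few compounds, and the source may have more. Where it says the series, first, only, none or still open, it means among the compounds named here.

Compound 1 `COc1cccc(/C=C/C(=O)C(=Cc2ccc(O)c(F)c2)C(=O)/C=C/c2cccc(OC)c2OC)c1OC` and compound 2 `COc1cc(C=C(C(=O)/C=C/c2cccc(OC)c2OC)C(=O)/C=C/c2cccc(OC)c2OC)cc(Br)c1O` are built on one shared core. In a functional assay on CNE-2 cells (Homo sapiens) for antiproliferative activity, read by sulforhodamine B assay, with a stated time of 48 h (on this read-out lower numbers stand for stronger inhibition and higher numbers for weaker inhibition), compound 1 gives 260 nM and compound 2 gives 220 nM. Between the two stands a single change, (3-bromo-4-hydroxy-5-methoxyphenyl in place of 3-fluoro-4-hydroxyphenyl on a double-bonded chain carbon bound to a double-bonded chain carbon), and it made a step of a 1.2-fold lower number from compound 1 to compound 2 (0.07 log units; within the scatter). Compound 3 `COc1cc(OC)c(/C=C/C(=O)C(=Cc2ccc(O)c(F)c2)C(=O)/C=C/c2c(OC)cc(OC)cc2OC)c(OC)c1` rests on a different core; the difference between the two cores is not broken down here. In this assay compound 3 gives 1580 nM, a higher number than either compound 1 or compound 2, which on this read-out means weaker inhibition. Compound 4 `COc1cc(OC)c(/C=C/C(=O)C(=Cc2cc(Br)c(O)c(OC)c2)C(=O)/C=C/c2c(OC)cc(OC)cc2OC)c(OC)c1` has not yet been measured. It differs from compound 3 by 3-bromo-4-hydroxy-5-methoxyphenyl in place of 3-fluoro-4-hydroxyphenyl on a double-bonded chain carbon bound to a double-bonded chain carbon, the same change that turns compound 1 into compound 2, made at the same place. Because the change on the core of compound 1 produced only a 1.2-fold lower number from compound 1 to compound 2 (0.07 log units; within the scatter), the step from compound 3 to compound 4 is expected to be small as well, roughly a 1.1-fold lower number from compound 3 to compound 4 (0.05 log units; within the scatter). Compound 4 is therefore estimated at 1400 nM. The lower end of the expected range for compound 4 is 700 nM. The upper end of the expected range for compound 4 is 2800 nM.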

Compound 4, half-maximal inhibitory concentration: 1320 nM
Estimate against measurement, compound 4: 1.1-fold (0.03 log units) above; the measured number falls inside the stated range.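

In this assay, the new step is a 1.2-fold lower number from compound 3 to compound 4 (0.08 log units; within the scatter), so the swap of 3-fluoro-4-hydroxyphenyl for 3-bromo-4-hydroxy-5-methoxyphenyl again leaves the number about where it was. Set beside the earlier step, the change behaves alike on the two cores: the same change on two cores in this assay, a 1.2-fold lower number (0.07 log units; within the scatter) from compound 1 to compound 2 and a 1.2-fold lower number (0.08 log units; within the scatter) from compound 3 to compound 4, 1.0-fold (0.01 log units) apart, within the scatter of two such steps. This shows that, in these two pairs, the change made no step larger than the usual scatter on either core, but it does not show that the change would stay this small on a third core, and since neither step stands out from the scatter, it cannot show how a change with a clear effect would carry over.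

The compounds shown leave open what happens when the ring at this place carries something other than a hydroxy group, such as an amine or a carboxylic acid. They also leave open whether a group without a halogen, such as a plain phenyl ring, would give a step of similar size on both cores.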